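Moving the fluorine on an inactive trifluoromethyl analogue

The source may hold more compounds than are shown below. What is called first, only, known or untested is meant among the compounds shown, and "the series" means these compounds.

Compound 1 `Cc1nc(-c2ccccc2F)c(C(=O)N2CCN(c3cccc(Cl)c3)CC2)o1` anchors this small set. In a functional assay on HL-60 cells (Homo sapiens) for inhibition, read by MTT assay, with a stated time of 72 h (on this read-out higher numbers stand for weaker inhibition and lower numbers for stronger inhibition), compound 1 gives 39.4 nM. Compound 2 `CC(C)(C)c1nc(-c2ccccc2F)c(C(=O)N2CCN(c3cccc(Cl)c3)CC2)o1` differs from it by tert-butyl in place of methyl on an aromatic carbon; in this assay compound 2 reaches only a limit of the assay, > 1000 nM. The step is an at least 25-fold higher number from compound 1 to compound 2 (1.40 log units; beyond the scatter). The value of compound 2 is the limit of > 1000 nM in this assay, at which 1 of the 3 values shown sits. Compound 3 `O=C(c1oc(C(F)(F)F)nc1-c1ccccc1F)N1CCN(c2cccc(Cl)c2)CC1` carries a trifluoromethyl group in place of that alkyl; in this assay compound 3 is reported as "not active" (no number reported), with no number given, so on the numbers shown it stands apart from compound 1 and alongside compound 2 rather than with it. Compound 4 `O=C(c1oc(C(F)(F)F)nc1-c1cccc(F)c1)N1CCN(c2cccc(Cl)c2)CC1` differs from compound 3 by 3-fluorophenyl in place of 2-fluorophenyl on an aromatic carbon. Among the compounds with values here, no measured step bears on this change: the only measured step, from methyl to tert-butyl, concerns a different group and is large, and nothing shows what a shift of the fluorine within the phenyl ring does. With compound 3 inactive, compound 4 is expected to stay weak in this assay, most likely again reported as a limit or as not active; its estimated value is 8000 nM, with a range from 1500 nM to 50000 nM.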

Compound 4, half-maximal inhibitory concentration: "not active" (no number reported)
Compound 4 has no reported number here; no gap can be computed for the estimate.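

In this assay compound 3 is reported as "not active" (no number reported), and compound 4 is reported as "not active" (no number reported), so no step can be read between them. The compounds shown leave open whether 3-fluorophenyl in place of 2-fluorophenyl changes the read-out at all, on this trifluoromethyl compound or on any other compound in the set.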